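Replacing pyridin-4-yl with 3-methylphenyl on a coumarin thioether

A few compounds are considered here, and "the series" means these few. Any claim that something is new, unique, unknown or untested is made for them only; others in the source may bear on it.

Compound 3 `Cc1cc(=O)oc2cc(SCc3ccncc3)ccc12` is one of three thioethers sharing a core. In a functional assay on A549 cells (Homo sapiens) for antiproliferative activity, read by sulforhodamine B assay, with a stated time of 72 h (on this read-out higher numbers stand for weaker inhibition of growth and lower numbers for stronger inhibition of growth), compound 3 reaches only a limit, > 35200 nM. Compound 1 `Cc1cc(=O)oc2cc(Sc3cccc(Cl)[n+]3[O-])ccc12` likewise gives only a limit in this assay, > 31200 nM. Compound 2 `Cc1cc(=O)oc2cc(SC3CCOC3=O)ccc12` also stops at a limit in this assay, > 36100 nM. With three limits and no number, compound 3 stands nowhere distinct among them. Compound 4 `Cc1cccc(CSc2ccc3c(C)cc(=O)oc3c2)c1` differs from compound 3 by 3-methylphenyl in place of pyridin-4-yl on a saturated chain carbon bound to a sulfur. For the measured compounds named here, no measured pair gives a step to lean on, so for compound 4 the expected step that the limit leaves unreadable from compound 3 to compound 4 in this assay is none beyond the scatter. Compound 4 is therefore estimated at 40000 nM, within 15000 nM to 120000 nM, most likely again a limit.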

Compound 4, concentration for 50% growth inhibition: > 33700 nM
Compound 4 gave a limit, no number; the forecaster's own chance of this, stated with the estimate: 80%; the middle value lies beyond the limit too.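

In this assay compound 4 gives only a limit, > 33700 nM. For the compounds shown here, compound 3 also gives only a limit, > 35200 nM, and no step between compound 3 and compound 4 can be read. The compounds shown leave open whether any thioether on the shared core gives a numerical value in this assay.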